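A few compounds are considered here, and "the series" means these few. Any claim that something is new, unique, unknown or untested is made for them only; others in the source may bear on it.

Working notes on the series. In a functional assay on SH-SY5Y cells (Homo sapiens) for cytotoxicity, read by MTT assay, with a stated time of 48 h (a lower number here means a stronger inhibitor, a higher number a weaker inhibitor), compound 1 `FC(F)=C(F)CCSc1nccs1` returns only a limit of the assay, > 120000 nM. Compound 3 `FC(F)(Cl)C(F)(Cl)CCSc1nc2ccccc2s1` likewise returns only a limit, > 120000 nM. Compound 2 `N#CC(C#N)=Cc1nccs1` also returns only a limit, > 120000 nM. Compound 2 therefore stands together with the other two, at the limit of > 120000 nM in this assay, at which 3 of the 3 values shown sit; no number separates any of the three, and nothing places compound 2 apart from them. Compound 4 `CC(=C(C#N)C#N)c1nccs1` differs from compound 2 by methyl in place of hydrogen on a double-bonded chain carbon bound to an aromatic carbon and a double-bonded chain carbon. For the measured compounds named here, no step between measured compounds is available to gauge this change; the step is expected to be none beyond the scatter, and the estimate means a step that the limit leaves unreadable from compound 2 to compound 4 in this assay. Compound 4 is expected to give 150000 nM, within 60000 nM to 400000 nM, most probably reported again only as a limit.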

Compound 4, half-maximal inhibitory concentration: 68800 nM
For compound 4 the middle estimate is 2.2-fold (0.34 log units) above the measured one; the range from low to high includes it.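

In this assay, compound 4 is the only compound shown with a readable number rather than a limit: the limit of > 120000 nM in this assay, at which 3 of the 4 values shown sit.

Methyl in place of hydrogen on a double-bonded chain carbon bound to an aromatic carbon and a double-bonded chain carbon gives an at least 1.7-fold lower number from compound 2 to compound 4 (0.24 log units; that floor lies within the scatter). This floor alone does not establish a change at this position beyond the scatter.

From the compounds shown here alone, compound 2 has only a limit, so the full size of the step stays open. Also open, going by these compounds, is what an ethyl group or an amine in place of the methyl would give.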